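The source may hold more compounds than are shown below. What is called first, only, known or untested is meant among the compounds shown, and "the series" means these compounds.

Compound 1, `COc1cc(-c2cc(/C=C/C(=O)c3ccc(N)cc3)[nH]n2)cc(OC)c1OC`: 5420 nM
Compound 2, `COc1ccc(-c2cc(/C=C/C(=O)c3ccc(N)cc3)[nH]n2)cc1OC`: 7190 nM

In a functional assay on SF-539 cells (Homo sapiens) for inhibition, read by sulforhodamine B assay, with a stated time of 48 h (a higher number here means that more compound is tolerated, a lower number that less compound is tolerated), compound 1 gives 5420 nM, the lowest of the two numbers. Compound 2 gives 7190 nM, and the step of a 1.3-fold higher number from compound 1 to compound 2 (0.12 log units; within the scatter) stays within the scatter. Compound 3, `COc1ccc(C(=O)/C=C/c2cc(-c3cc(OC)c(OC)c(OC)c3)n[nH]2)cc1OC`, is not yet measured; it differs from compound 1 as follows: 3,4-dimethoxyphenyl in place of 4-aminophenyl on a carbonyl carbon. Among the compounds with values here, no measured step changes the group on the carbonyl carbon, so the step of a 1.3-fold higher number from compound 1 to compound 2 (0.12 log units; within the scatter) does not bear on this change. Lacking a guide, no step beyond the scatter is expected in this assay, though the uncertainty is wide. Compound 3 is therefore estimated at 6000 nM, with a range from 1500 nM to 25000 nM, which means an expected step of a 1.1-fold higher number from compound 1 to compound 3 (0.04 log units; within the scatter).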

Compound 3, concentration lethal to 50% of the cells: 5310 nM
Compound 3: middle estimate off by 1.1-fold (0.05 log units), on the high side; low and high end bracket the measured number.
By their numbers in this assay, from the lowest: compounds 3, 1 and 2 (each within the scatter of the next).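

In this assay, 3,4-dimethoxyphenyl in place of 4-aminophenyl on the carbonyl carbon gives a 1.0-fold lower number from compound 1 to compound 3 (0.01 log units; within the scatter). Within the data shown here, this is the first look at this position, and here a larger group with no hydrogen-bond donor reads the same as the 4-aminophenyl group, so the amino group is not required for this number in this pair. Nothing available explains why the two groups read alike. Still open, from the compounds shown here alone, is whether any group on this carbon moves the number beyond the scatter: a phenyl carrying a carboxylic acid, say, or a small methyl with no ring at all.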